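The compounds below may be only part of what the source reports. "The series", "measured", "known", "first", "only" and "open" are said of these compounds alone.

Working notes on the series. Going by the values given here, in a toxicity assay on MT4 cells (Homo sapiens) for cytotoxicity, read by MTT assay (on this read-out higher numbers stand for lower toxicity in this test and lower numbers for higher toxicity in this test), compound 1 (`Cc1ccccc1-c1cc(C)c(Oc2cc(N)nc(Nc3ccc(C#N)cc3)n2)c(C)c1`) gives 25600 nM and compound 2 (`COc1ccc(-c2cc(C)c(Oc3cc(N)nc(Nc4ccc(C#N)cc4)n3)c(C)c2)cc1`) gives 10700 nM as the lower of the two numbers so far. Compound 3 (`Cc1cc(-c2ccc(C#N)c(F)c2)cc(C)c1Oc1cc(N)nc(Nc2ccc(C#N)cc2)n1`) carries 4-cyano-3-fluorophenyl in place of 4-methoxyphenyl on an aromatic carbon, meta to two methyl groups (counted: 4-cyano-3-fluorophenyl in place of 4-methoxyphenyl on an aromatic carbon). Among the compounds with values here, one measured step bears on this change: a 2.4-fold lower number from compound 1 to compound 2 (0.38 log units; beyond the scatter) is modest, and it also exchanges one substituted phenyl group for another on an aromatic carbon. Within the data shown here, with only that step to go on, a modest step or none beyond the scatter is expected in this assay with no firm direction. The expected move is a 1.1-fold higher number from compound 2 to compound 3 (0.05 log units; within the scatter) at this stage. For compound 3 the estimated value is 12000 nM with an expected range of 4500 nM to 32000 nM in this read-out.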

Compound 3, half-maximal cytotoxic concentration: 5000 nM
Beside the measured number, compound 3's estimate is 2.4-fold (0.38 log units) above it; the measured number falls inside the stated range.
By their numbers in this assay, from the lowest: compound 3; then compound 2; then compound 1.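

In this assay the position meta to two methyl groups responds a second time to an exchange of one substituted phenyl group for another: a 2.1-fold lower number from compound 2 to compound 3 (0.33 log units; beyond the scatter) is a step of similar modest size to a 2.4-fold lower number from compound 1 to compound 2 (0.38 log units; beyond the scatter) and runs the same way. Over the full span, a 5.1-fold lower number from compound 1 to compound 3 (0.71 log units; beyond the scatter) shows that 4-cyano-3-fluorophenyl gives the highest toxicity in this test among the three compounds, with both of its steps beyond the scatter. No measurement at hand accounts for this shift.

Going by these compounds alone, since the nitrile and the fluorine enter together in compound 3, it stays open which of them, or whether only the pair, goes with the lower number. Also open, on these data alone, is how an amine, a carboxylic acid or a morpholine at this position would read in this assay and whether the downward trend would hold.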